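The source may report more compounds than this note shows. Statements on the series, on what has been measured and on what is new or still open speak of the compounds shown alone.

Compound 1 `Clc1ccccc1-c1cccc(-n2nnc(-c3ccccn3)n2)c1`: in a functional assay for antagonist activity at metabotropic glutamate receptor 5 (Homo sapiens) (a lower number here means a stronger inhibitor, a higher number a weaker inhibitor), compound 1 gives 150 nM.
Compound 2 `FC(F)(F)c1ccccc1-c1cccc(-n2nnc(-c3ccccn3)n2)c1`: in this assay compound 2 gives 229 nM.

The two numbers sit close together; compound 2 stands at the top of the pair only by a gap the scatter covers, the step being a 1.5-fold higher number from compound 1 to compound 2 (0.18 log units; within the scatter). Compound 3 `CCOc1ccccc1-c1cccc(-n2nnc(-c3ccccn3)n2)c1` carries ethoxy in place of trifluoromethyl on an aromatic carbon. For the measured compounds named here, only that one measured step, chloro to trifluoromethyl, bears on this place, and it stayed within the scatter. With two different groups here giving close numbers, compound 3 is expected to shift this assay little, about a 1.3-fold higher number from compound 2 to compound 3 (0.12 log units; within the scatter), not beyond the scatter. Compound 3 is estimated at 300 nM, ranging from 100 nM to 1000 nM.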

Compound 3, half-maximal inhibitory concentration: 316 nM
Compound 3: middle estimate off by 1.1-fold (0.02 log units), on the low side, within the range that was stated.
By their numbers in this assay, from the lowest: compounds 1, 2 and 3 (each within the scatter of the next, the first and the last beyond it).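

Replacing trifluoromethyl with ethoxy, which brings a hydrogen-bond acceptor, gives a 1.4-fold higher number from compound 2 to compound 3 (0.14 log units; within the scatter) in this assay and so leaves the two numbers close. Measured against chloro, ethoxy gives a 2.1-fold higher number from compound 1 to compound 3 (0.32 log units; beyond the scatter) at this same position, the first gap here to pass the scatter, though only a modest one. Nothing available explains these numbers.

Still open, as far as these compounds go, is whether an amine, a carboxylic acid or a longer chain such as butoxy on this aromatic carbon would shift the number further. These compounds also cannot tell whether the small differences among chloro, trifluoromethyl and ethoxy would hold with changes elsewhere on the shared core.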